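Removing one chloro from compound 2: expected effect on cytotoxicity

The source may report more compounds than this note shows. Statements on the series, on what has been measured and on what is new or still open speak of the compounds shown alone.

Measured compounds:
compound 1 `Nc1nc(Cl)c2ncn(Cc3ccccc3CCl)c2n1`: "not determined" (no result reported)
compound 2 `ClCc1ccccc1Cn1cnc2nc(Cl)nc(Cl)c21`: 1900 nM

Among the compounds with values here, in a functional assay on RXF 393 cells (Homo sapiens) for cytotoxicity, read by sulforhodamine B assay, with a stated time of 48 h (a higher number here means a weaker inhibitor of growth, a lower number a stronger inhibitor of growth), compound 2 gives 1900 nM, the only number available, since compound 1 has no result in this assay. Compound 3 `ClCc1ccccc1Cn1cnc2ncnc(Cl)c21` differs from compound 2 by hydrogen in place of chloro on an aromatic carbon. Within the data shown here, no step between measured compounds exists to calibrate this change, so its size can only be guessed; a small shift, toward weaker growth inhibition but within the usual scatter, is expected. Compound 3 is therefore expected to give 2600 nM, in a range from 800 nM to 8000 nM. The expected step is a 1.4-fold higher number from compound 2 to compound 3 (0.14 log units; within the scatter).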

Compound 3, concentration for total growth inhibition: 6540 nM
Compound 3: the middle estimate sits 2.5-fold (0.40 log units) below what was measured; low and high end bracket the measured number.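

In this assay, putting hydrogen in place of the chloro between two ring nitrogen atoms gives a 3.4-fold higher number from compound 2 to compound 3 (0.54 log units; beyond the scatter). Within the data shown here, this is the first sign that the chloro at this position counts: the step lies beyond the scatter, and growth inhibition weakens without it. Nothing shown explains why the number moves.

The step from compound 1, which has an amine at this position, cannot be read, as compound 1 has no result. As far as these compounds go, how a methyl or methoxy group would behave here remains open.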